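A few compounds are considered here, and "the series" means these few. Any claim that something is new, unique, unknown or untested is made for them only; others in the source may bear on it.

Compound 2, with the structure `CN(C)c1ncnc2c1c(-c1cc3ccccc3o1)cn2[C@@H]1O[C@H](CO)[C@@H](O)[C@H]1O`, sits at the weak end of what has been measured: in a functional assay on K562 cells (Homo sapiens), read by MTT assay, with a stated time of 72 h (a higher number here means a weaker inhibitor, a lower number a stronger inhibitor), compound 2 gives > 20000 nM, which is a limit of the assay and not a number, as noted in the limit of > 20000 nM in this assay, at which 1 of the 3 values shown sits. For the measured compounds named here, compound 3, with the structure `C#Cc1cn([C@@H]2O[C@H](CO)[C@@H](O)[C@H]2O)c2ncnc(N(C)C)c12`, gives 260 nM in this assay, and the step of an at least 76-fold lower number from compound 2 to compound 3 (1.88 log units; beyond the scatter) is the only measured step here; it changes a different part of the molecule and does not bear on the change now considered. Compound 1, with the structure `COc1nc(N)nc2c1c(-c1cc3ccccc3o1)cn2[C@@H]1O[C@H](CO)[C@@H](O)[C@H]1O`, gives 15500 nM in this assay, and it carries both a methoxy and a 1-benzofuran-2-yl group, so it is the nearest point of comparison. Compound 4, with the structure `COc1ncnc2c1c(-c1cc3ccccc3o1)cn2[C@@H]1O[C@H](CO)[C@@H](O)[C@H]1O`, differs from compound 2 by methoxy in place of dimethylamino on an aromatic carbon. Going by the values given here, with no measured step for this change, compound 4 is expected to remain weak, and the step of a number no higher from compound 2 to compound 4 (the limit leaves the size open) is expected to lie within the scatter. Compound 4 is therefore estimated at 20000 nM in this assay, within a range from 8000 nM to 50000 nM.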

Compound 4, half-maximal inhibitory concentration: 13100 nM
Compound 4: the middle estimate sits 1.5-fold (0.18 log units) above what was measured, within the range that was stated.
By their numbers in this assay, from the lowest: compound 3; then compounds 4 and 1 (each within the scatter of the next). At a limit, above all of these: compound 2.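

Methoxy in place of dimethylamino on this aromatic carbon, next to the ring nitrogen, gives an at least 1.5-fold lower number from compound 2 to compound 4 (0.18 log units; that floor lies within the scatter) in this assay. Compound 2 stands at a limit of the assay and not at a number, so this step has a floor but no known size: the limit of > 20000 nM in this assay, at which 1 of the 4 values shown sits. With methoxy held in place, hydrogen in place of amino gives a 1.2-fold lower number from compound 1 to compound 4 (0.07 log units; within the scatter), so in this assay the amino group makes no difference that can be told from the scatter.

On these data alone, whether methoxy behaves the same way with ethynyl in place of 1-benzofuran-2-yl stays open. Also open, as far as these compounds go, is how an unsubstituted amine, an ethoxy group or a chlorine atom would read at this position.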